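This account rests on a few compounds, and the source may have more. Where it says the series, first, only, none or still open, it means among the compounds named here.

In a functional assay (a higher number here means a weaker inhibitor, a lower number a stronger inhibitor), compound 1 (`CC(C)=CCOc1ccc2c(c1)OC(c1ccccc1)CC2=O`) gives 6070 nM, compound 2 (`CC(C)=CCOc1ccc2c(c1)OC(c1ccc(Br)cc1)CC2=O`) gives 8120 nM, and compound 3 (`CC(C)=CCOc1cc(O)c2c(c1)OC(c1ccccc1)CC2=O`) gives 7320 nM, which places compound 3 within the scatter of both others. Compound 4 (`CC(C)=CCOc1cc(O)c2c(c1)OC(c1ccc(F)cc1)CC2=O`) differs from compound 3 in one place: fluoro in place of hydrogen on an aromatic carbon. For the measured compounds named here, two measured steps bear on this change. The closer is the bromo step, a 1.3-fold higher number from compound 1 to compound 2 (0.13 log units; within the scatter), and the other is the hydroxy step, a 1.2-fold higher number from compound 1 to compound 3 (0.08 log units; within the scatter). Both stay within the scatter, so no step beyond it is expected in this assay. The expected step is a 1.0-fold higher number from compound 3 to compound 4 (0.01 log units; within the scatter). Compound 4 is estimated at 7500 nM, with an expected range of 3500 nM to 15000 nM.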

Compound 4, half-maximal inhibitory concentration: 6060 nM
Beside the measured number, compound 4's estimate is 1.2-fold (0.09 log units) above it; low and high end bracket the measured number.
By their numbers in this assay, from the lowest: compounds 4, 1, 3 and 2 (each within the scatter of the next).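

In this assay the change from phenyl to 4-fluorophenyl, with the hydroxy present, gives a 1.2-fold lower number from compound 3 to compound 4 (0.08 log units; within the scatter) and so stays within the scatter. The earlier bromo step, a 1.3-fold higher number from compound 1 to compound 2 (0.13 log units; within the scatter), was also within the scatter, so at this place on the ring two halogens, on two different parent compounds, leave the number within the scatter. Nothing available explains the size of either step. On these data alone, whether an amine or a carboxylic acid at this place would move the number beyond the scatter stays open. So does the effect of fluoro on compound 1.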